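Removing one hydroxy group from compound 3

The source may hold more compounds than are shown below. What is called first, only, known or untested is meant among the compounds shown, and "the series" means these compounds.

In an ADME assay on MDCK cells (Canis lupus familiaris) for cytotoxicity, read by MTT assay, with a stated time of 72 h (a lower number here means a stronger inhibitor, a higher number a weaker inhibitor), the measured compounds read as follows
- Compound 1 `Cc1cc(/C=C/c2ccc(O)cc2)[nH]n1` gives 80000 nM
- Compound 2 `COc1ccc(/C=C/C(=O)CC(C)=O)cc1OC` gives 9900 nM
- Compound 3 `Cc1cc(/C=C/c2ccc(O)c(O)c2)on1` gives 11600 nM

Compound 3 at 11600 nM lies within the usual scatter of compound 2 and clearly below compound 1. Compound 4 `Cc1cc(/C=C/c2ccc(O)cc2)on1` differs from compound 3 at one place hydrogen in place of hydroxy on an aromatic carbon with hydrogen in place of hydroxy on an aromatic carbon, ortho to a hydroxy group. Within the data shown here, no measured pair isolates this change. Compound 1 also carries hydrogen at that place and gives 80000 nM on a different core, so in this assay a rise beyond the scatter is expected. The expected size is a 2.4-fold higher number from compound 3 to compound 4 (0.38 log units; beyond the scatter) in this estimate. Compound 4 is estimated at 28000 nM with an expected range from 11000 nM to 70000 nM in repeat measurements.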

Compound 4, half-maximal inhibitory concentration: 58300 nM
For compound 4 the middle estimate is 2.1-fold (0.32 log units) below the measured one; the measured number falls inside the stated range.
By their numbers in this assay, from the lowest: compounds 2 and 3 (each within the scatter of the next); then compounds 4 and 1 (each within the scatter of the next).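

In this assay, the measured pair now isolates this change: replacing the hydroxy group on an aromatic carbon, ortho to a hydroxy group, with hydrogen gives a 5.0-fold higher number from compound 3 to compound 4 (0.70 log units; beyond the scatter). So on this shared core the position is sensitive, and the extra hydroxy group goes with the lower number. Nothing measured here explains why the number rises. The compounds shown compare only hydroxy and hydrogen at this position, so how an amine or a fluorine atom there would read stays open.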